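Amide-end change on the weakest member, compound 1

This account rests on a few compounds, and the source may have more. Where it says the series, first, only, none or still open, it means among the compounds named here.

Measured so far in a functional assay on BXPC-3 cells (Homo sapiens) for inhibition, read by MTT assay, with a stated time of 7 days; a lower number here means a stronger inhibitor, a higher number a weaker inhibitor:
compound 1 `CCN(CC)S(=O)(=O)c1ccc(S(=O)(=O)N2CCC[C@@H](C(=O)N3CCC(O)CC3)C2)cc1` — 4710 nM
compound 2 `CC(C)S(=O)(=O)c1ccc(S(=O)(=O)N2CCC[C@@H](C(=O)N3CCC(F)(F)CC3)C2)cc1` — 50 nM
compound 3 `CN(C)S(=O)(=O)c1ccc(S(=O)(=O)N2CCC[C@@H](C(=O)N3CCC(F)(F)CC3)C2)cc1` — 560 nM

Compound 1 stands at the highest number of the three in this assay; compound 3 is nearest and compound 2 furthest. Among the measured compounds shown here, the only single-point step measured, an 11-fold higher number from compound 2 to compound 3 (1.05 log units; beyond the scatter), concerns the group on the sulfonyl sulfur and leaves the amide end untouched. Compound 4 `CCN(CC)S(=O)(=O)c1ccc(S(=O)(=O)N2CCC[C@@H](C(=O)N[C@@H]3CCOC3)C2)cc1` differs from compound 1 by (oxolan-3-yl)amino in place of 4-hydroxypiperidin-1-yl on a carbonyl carbon. For the measured compounds named here, no measured pair isolates this change; compound 1 and compound 3 differ in two places, so their gap cannot be assigned to the amide end alone. With nothing bearing on it, the step of a 1.2-fold lower number from compound 1 to compound 4 (0.07 log units; within the scatter) is expected to stay within the scatter. Compound 4 is therefore estimated at 4000 nM, in the range 1200 nM to 13000 nM.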

Compound 4, half-maximal inhibitory concentration: 2270 nM
Estimate against measurement, compound 4: 1.8-fold (0.25 log units) above, and the stated range covers the measured number.
By their numbers in this assay, from the lowest: compound 2; then compound 3; then compound 4; then compound 1.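

In this assay, among the compounds shown here, a 2.1-fold lower number from compound 1 to compound 4 (0.32 log units; beyond the scatter) gives the first measured step at the amide end, with the group on the sulfonyl sulfur held fixed; the position accepts this exchange with a modest gain. The step changes ring size and adds a defined stereocentre while the donor and acceptor counts stay the same, so it cannot be assigned to one feature. No available measurement explains the step. Still open, going by these compounds, are the opposite stereocentre of the (oxolan-3-yl)amino group, an open-chain amine such as 2-methoxyethylamine at this carbonyl carbon, and whether the step carries over with isopropyl on the sulfonyl sulfur.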